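Benzyl carbamates in the triazole series: working notes

The source may report more compounds than this note shows. Statements on the series, on what has been measured and on what is new or still open speak of the compounds shown alone.

Measured so far, in an assay on nucleic acid for inhibition of Nucleic Acid, read by fluorescence, tested at 100 uM; on this read-out lower numbers stand for less inhibition and higher numbers for more inhibition at the one concentration tested (going by the name of the read-out):
compound 1, `CCCCNC(=O)OCC(O)Cn1cc(CN2CCCC(C(=O)OCC)C2)nn1`, gives 24%
compound 2, `CCOC(=O)C1CCCN(Cc2cn(CC(O)COC(=O)NCc3ccccc3)nn2)C1`, gives 47%
compound 3, `CCCCNC(=O)OCC(O)Cn1cc(CN(C)CC2CCCCC2)nn1`, gives 12%

Compound 3 stands lowest of the three, beyond the scatter from both others. Its core differs from that of compound 1 by more than one place; that difference is not broken down here. Compound 1 and compound 2 differ by phenyl in place of propyl on a saturated chain carbon bound to an amide-type nitrogen, and this change gave a number 23 percentage points higher from compound 1 to compound 2 (beyond the scatter) in this assay.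

Compound 4, `CN(Cc1cn(CC(O)COC(=O)NCc2ccccc2)nn1)CC1CCCCC1`, is not yet measured. It differs from compound 3 by phenyl in place of propyl on a saturated chain carbon bound to an amide-type nitrogen, the same change, at the same place. Compound 4 is therefore expected to rise by a number 23 percentage points higher from compound 3 to compound 4 (beyond the scatter) in this assay, a step of about the size seen from compound 1 to compound 2, resting on that single pair alone. The estimate for compound 4 in this assay is 35%, with a range from 18% to 52%.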

Compound 4, a percentage reported as inhibition, at one concentration (the size of the read-out at that concentration, not a potency): 32%
Compound 4: the middle estimate sits 3 percentage points above what was measured; the range from low to high includes it.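

Phenyl in place of propyl on a saturated chain carbon bound to an amide-type nitrogen gave a number 20 percentage points higher from compound 3 to compound 4 (beyond the scatter) in this assay. The change carries from one core to the other at much the same size: the same change on two cores in this assay, a number 23 percentage points higher (beyond the scatter) from compound 1 to compound 2 and a number 20 percentage points higher (beyond the scatter) from compound 3 to compound 4, 3 percentage points apart, within the scatter of two such steps. This rests on two pairs only, so it supports carrying the change between the core of compound 1 and the core of compound 3, but it says nothing about other cores or about why the step arises, and each number comes from a single concentration, so none of this is a potency.

Still open, as far as these compounds go, is whether a longer chain at this place would give a similar step. From the compounds shown here alone, a phenyl carrying a carboxylic acid or an amine is equally open.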